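Swapping a Bromophenyl Arm for a Methoxyphenyl Arm

This account rests on a few compounds, and the source may have more. Where it says the series, first, only, none or still open, it means among the compounds named here.

Compound 1, `C=CCn1c(=O)/c(=C\c2cc(F)ccc2C)[nH]c(=O)/c1=C\c1ccccc1OC`: 2900 nM
Compound 2, `C=CCn1c(=O)/c(=C\c2ccc(F)c(Br)c2)[nH]c(=O)/c1=C\c1ccccc1OC`: "not active" (no number reported)
Compound 3, `C=CCn1c(=O)/c(=C\c2cccc(Br)c2)[nH]c(=O)/c1=C\c1ccccc1OC`: 5400 nM

All three compounds share one core and differ only in the aryl group carried on one of its double-bonded chain carbons. In a functional assay on HeLa cells (Homo sapiens) for cytotoxicity, read by CCK-8 assay, with a stated time of 72 h (a lower number here means a stronger inhibitor, a higher number a weaker inhibitor), compound 1 gives 2900 nM. Compound 2 gives "not active" (no number reported), so no number is available for it. Compound 3 gives 5400 nM, the highest of the two numbers reported; the nearest is compound 1, and the step of a 1.9-fold higher number from compound 1 to compound 3 (0.27 log units; within the scatter) lies within the scatter.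

Compound 4, `C=CCn1c(=O)/c(=C\c2ccccc2OC)[nH]c(=O)/c1=C\c1ccccc1OC`, changes that same aryl group: 2-methoxyphenyl in place of 3-bromophenyl on a double-bonded chain carbon bound to an aromatic carbon. Both arms of compound 4 then carry the same 2-methoxyphenyl. Within the data shown here, only one measured step bears on such a swap, a 1.9-fold higher number from compound 1 to compound 3 (0.27 log units; within the scatter), and it is small. Among the measured compounds shown here, no measured compound carries a 2-methoxyphenyl at this place, and compound 2 shows that a change of aryl group can remove activity altogether. The expected step is therefore none beyond the scatter, a 1.4-fold lower number from compound 3 to compound 4 (0.13 log units; within the scatter). Compound 4 is estimated at 4000 nM, with a range from 1500 nM to 12000 nM.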

Compound 4, half-maximal inhibitory concentration: 6900 nM
Estimate against measurement, compound 4: 1.7-fold (0.24 log units) below; measured number inside the range.
By their numbers in this assay, from the lowest: compounds 1, 3 and 4 (each within the scatter of the next, the first and the last beyond it).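

At this place on the shared core, 2-methoxyphenyl still gives a number in this assay and the swap for 3-bromophenyl gives a 1.3-fold higher number from compound 3 to compound 4 (0.11 log units; within the scatter) and so no real difference between these two groups. Among these compounds, the swap for 5-fluoro-2-methylphenyl gives a 2.4-fold higher number from compound 1 to compound 4 (0.38 log units; beyond the scatter) and is the first measured step at this place to clear the usual scatter, though only modestly, so among aryl groups that give a number the choice can matter a little. No measurement here accounts for either step.

The compounds shown all carry an aryl group here, leaving open what an amine, a carboxylic acid or a longer chain would do at this place. They also leave open why compound 2 yields no number while compounds 1, 3 and 4 do.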